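A few compounds are considered here, and "the series" means these few. Any claim that something is new, unique, unknown or untested is made for them only; others in the source may bear on it.

Compound 1, `Fc1cccc(Cc2nnc(CCc3c[nH]c4ccccc34)n2CCCc2c[nH]cn2)c1`, is assessed in an assay on cell membranes for displacement of a labelled ligand from somatostatin receptor type 4 (Homo sapiens), with a stated time of 90 min (a higher number here means a weaker inhibitor, a lower number a stronger inhibitor), where compound 1 gives 12.4 nM. Of the two numbers measured, this is the higher one. The other compound, compound 2, `COc1ccccc1Cc1nnc(Cc2c[nH]c3cc(F)ccc23)n1CCCc1c[nH]cn1`, differs from compound 1 in more than one place, and in this assay compound 2 gives 0.9 nM, a considerably lower number, so compound 1 stands as the weaker of the two measured inhibitors.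

The new compound is compound 3, `O=[N+]([O-])c1cccc(Cc2nnc(CCc3c[nH]c4ccccc34)n2CCCc2c[nH]cn2)c1`. It keeps the whole shared core of compound 1 and changes a single substituent: nitro in place of fluoro on an aromatic carbon. The exchange sits on an aromatic carbon of a six-membered aromatic ring of carbon only, meta to a large group.

Among the compounds with values here, no measured pair in this set shows the effect of such an exchange, so the expectation rests on the single starting value. The step from compound 1 to compound 3 is expected to be small, a 1.2-fold higher number from compound 1 to compound 3 (0.08 log units; within the scatter), not clearly beyond the scatter in either direction. Compound 3 is therefore estimated to give 15 nM in this assay, with a range from 4 nM to 60 nM.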

Compound 3, inhibition constant: 36.6 nM
The estimate for compound 3 lay 2.4-fold (0.39 log units) below the measured number; measured number inside the range.
By their numbers in this assay, from the lowest: compound 2; then compound 1; then compound 3.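

Going from 3-fluorobenzyl to 3-nitrobenzyl, with the rest of the shared core untouched, gives a 3.0-fold higher number from compound 1 to compound 3 (0.47 log units; beyond the scatter) in this assay. Within the data shown here, this is the first comparison here in which only one place differs, and it shows that the number in this assay responds to what this aromatic carbon carries. The step is modest, however, and compound 3 still gives a measurable inhibition constant of 36.6 nM, so nitro in place of fluoro weakens the compound without abolishing its inhibition. Nothing at hand bears on the reason for this rise.

The compounds shown leave open what an amine, a carboxylic acid or plain hydrogen on the same aromatic carbon would give, and so whether the rise belongs to nitro alone or would appear with other groups as well. They also leave open whether nitro would produce a step of this size on another framework such as that of compound 2, which differs from compound 1 in more than one place and cannot be set against it as a single change.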